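The source may hold more compounds than are shown below. What is called first, only, known or untested is meant among the compounds shown, and "the series" means these compounds.

Working notes on the series. Compound 1 `Cn1c(=O)c2ccccc2c(=O)n1CCCNC(=O)OC(C)(C)C` gives 23600 nM in a functional assay on aorta (Rattus norvegicus, strain Wistar) for inhibition; on this read-out higher numbers stand for an effect only at larger amounts of compound and lower numbers for an effect already at smaller amounts. Compound 2 `Cn1c(=O)c2c(Cl)cccc2c(=O)n1CCCN` gives 30200 nM in this assay, the highest number of the three; compound 1 sits a short way beneath it, within the scatter, so no order between compound 2 and compound 1 can be read. Compound 3 `Cn1c(=O)c2cccc(Cl)c2c(=O)n1CCCBr` gives 6710 nM in this assay, beneath compound 2 by a gap beyond the scatter; compound 3 differs from compound 2 in more than one place, so that gap cannot be assigned to a single change.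

Compound 4 `Cn1c(=O)c2c(Cl)cccc2c(=O)n1CCCN=[N+]=[N-]` is not yet measured. It differs from compound 2 by azido in place of amino on a saturated chain carbon, three bonds along the chain from an aromatic nitrogen. Within the data shown here, no single-point step between measured compounds exists to calibrate this change; the only guidance is that compound 1, which likewise carries no amino group at the chain end, lies within the scatter of compound 2. The step of a 1.9-fold lower number from compound 2 to compound 4 (0.28 log units; within the scatter) is expected to be small, towards a lower number if anything, and may stay within the scatter. For compound 4 the estimate in this assay is 16000 nM, with a range from 5000 nM to 50000 nM.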

Compound 4, half-maximal effective concentration: 11700 nM
The estimate for compound 4 lay 1.4-fold (0.14 log units) above the measured number; the range from low to high includes it.
By their numbers in this assay, from the lowest: compounds 3, 4, 1 and 2 (each within the scatter of the next, the first and the last beyond it).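

In this assay, the series now has its first step that changes one place only: azido in place of amino on a saturated chain carbon, three bonds along the chain from an aromatic nitrogen, gives a 2.6-fold lower number from compound 2 to compound 4 (0.41 log units; beyond the scatter) on the shared core. The chain end of compound 2 is therefore a place where a single change moves the number beyond the scatter, and the lower number comes with azido, which has 0 hydrogen-bond donors, where amino has 1. No measurement on hand bears on the reason for this step.

Compounds 1 and 3 differ from compound 4 in more than one place, so those steps cannot be read. On these data alone, whether a carboxylic acid, a hydroxyl group or a longer chain carrying azido would lower the number further stays open.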